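Swapping carbamoyl for hydroxymethyl on a well-tolerated core

This account rests on a few compounds, and the source may have more. Where it says the series, first, only, none or still open, it means among the compounds named here.

Of the compounds shown here, three sharing one core have been tested in an ADME assay on MT4 cells (Homo sapiens) for cytotoxicity, read by MTT assay; a higher number here means that more compound is tolerated, a lower number that less compound is tolerated. Compound 1 (`NC(=O)c1cn([C@H]2C[C@H](O)[C@@H](CO)O2)c(=O)[nH]c1=O`) gives > 200000 nM, which is a limit of the assay and not a number. Compound 2 (`O=c1[nH]c(=O)n([C@H]2C[C@H](O)[C@@H](CO)O2)cc1O`) gives > 200000 nM, again only a limit. Compound 3 (`NC(=O)c1cn([C@H]2C[C@H](O)[C@@H](CO)O2)c(=O)nc1N`) gives > 200000 nM, also a limit. Compound 3 therefore has no exact number, and the whole set shows (the limit of > 200000 nM in this assay, at which 3 of the 3 values shown sit).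

The next compound is compound 4 (`Nc1nc(=O)n([C@H]2C[C@H](O)[C@@H](CO)O2)cc1CO`), in which hydroxymethyl replaces carbamoyl on an aromatic carbon, ortho to an amino group: hydroxymethyl in place of carbamoyl on an aromatic carbon. The nearest measured change also removes carbamoyl from an aromatic carbon, though hydroxy comes in there: a step that the two limits leave unreadable from compound 1 to compound 2. Neither end of that step is a number, so it offers no size to carry over, but neither compound has come down from the limit. On this evidence, no step beyond the usual scatter is expected in this assay, and no direction can be named. The expected change is a number no higher from compound 3 to compound 4 (the limit leaves the size open). Compound 4 will most likely be reported as a limit again. As a number, compound 4 is estimated at about 200000 nM, with an expected range from 100000 nM to 400000 nM.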

Compound 4, half-maximal cytotoxic concentration: > 200000 nM
Compound 4 gave a limit, no number; the forecaster's own chance of this, stated with the estimate: 85%; the middle value sits exactly at the limit.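

Compound 3 and compound 4 both give a limit of the assay rather than a number, so no step can be read between them in this assay. The compounds shown leave open whether hydroxymethyl and carbamoyl differ at all here, and at what concentration any of these compounds would become cytotoxic, because every result rests at the same limit: the limit of > 200000 nM in this assay, at which 4 of the 4 values shown sit.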